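This account rests on a few compounds, and the source may have more. Where it says the series, first, only, none or still open, it means among the compounds named here.

Measured compounds so far:
Compound 1 `O=C(CSc1nnc(NC(=O)c2c(Cl)cccc2Cl)s1)Nc1ccc(Br)cn1`: in a functional assay on A875 cells (Homo sapiens) for antiproliferative activity, read by MTT assay, with a stated time of 48 h (a higher number here means a weaker inhibitor, a lower number a stronger inhibitor), compound 1 gives 18600 nM.
Compound 2 `COc1ccccc1C(=O)Nc1nnc(SCC(=O)Nc2c(C)ccnc2Cl)s1`: in this assay compound 2 gives only a limit, > 80000 nM.
Compound 3 `O=C(CSc1nnc(NC(=O)C(Cl)Cl)s1)Nc1ccc(Br)cn1`: in this assay compound 3 gives 6500 nM.

Compound 1 holds the highest of the two numbers in this assay; the nearest number is that of compound 3. For the measured compounds named here, the single measured step in the set is a 2.9-fold lower number from compound 1 to compound 3 (0.46 log units; beyond the scatter), a modest one that lies beyond the scatter. Going by the values given here, compound 2 contributes no number, only a limit, (the limit of > 80000 nM in this assay, at which 1 of the 3 values shown sits), and so gives no step.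

Compound 4 `O=C(CSc1nnc(NC(=O)CCCl)s1)Nc1ccc(Br)cn1` is not yet measured in this assay. It differs from compound 1 by 2-chloroethyl in place of 2,6-dichlorophenyl on a carbonyl carbon. The step that bears on this change is a 2.9-fold lower number from compound 1 to compound 3 (0.46 log units; beyond the scatter), since there too the aryl group on the carbonyl carbon gave way to a short chlorinated alkyl group. A step of comparable size and the same direction is therefore expected, namely a 2.1-fold lower number from compound 1 to compound 4 (0.32 log units; beyond the scatter), with the lower number not guaranteed to clear the scatter. In this assay compound 4 is estimated at 9000 nM, within a range from 3500 nM to 25000 nM.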

Compound 4, half-maximal inhibitory concentration: 430 nM
The estimate for compound 4 lay 21-fold (1.32 log units) above the measured number, and the stated range ends above it.
By their numbers in this assay, from the lowest: compound 4; then compound 3; then compound 1. At a limit, above all of these: compound 2.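

At this position, on a carbonyl carbon whose other neighbour is the amide-type nitrogen, the outcome in this assay depends strongly on which short chlorinated alkyl group replaces 2,6-dichlorophenyl: 2-chloroethyl gives a 43-fold lower number from compound 1 to compound 4 (1.64 log units; beyond the scatter) against a 2.9-fold lower number from compound 1 to compound 3 (0.46 log units; beyond the scatter) for dichloromethyl. With a 15-fold lower number from compound 3 to compound 4 (1.18 log units; beyond the scatter) as the gap between the two alkyl groups, loss of the aromatic ring does not act as one uniform change, and the earlier step showed only part of what this position allows. Among the three compounds with numbers, which differ only at this position, compound 4 is the strongest, with its steps to the other two printed as beyond the scatter.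

No measurement shown here accounts for the gain with 2-chloroethyl, so its origin remains unexplained. Still open, on these data alone, is whether the gain depends on the chlorine or on the chain, which a plain propyl group, a longer 3-chloropropyl chain or a dimethylamino group in place of the chlorine would begin to separate.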